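Swapping the ester tail of compound 3 for a thioether

This account rests on a few compounds, and the source may have more. Where it says the series, first, only, none or still open, it means among the compounds named here.

Of the compounds shown here, three built on one shared core have so far been measured in an assay for inhibition of Fatty-acid amide hydrolase 1 (Rattus norvegicus), using a Dixon plot; a lower number here means a stronger inhibitor, a higher number a weaker inhibitor. Compound 1 `O=Cc1ccc(-c2cnc(C(=O)CCCCCCc3ccccc3)o2)nc1` gives 2.2 nM, compound 2 `CCOS(=O)(=O)/C=C/c1ccc(-c2cnc(C(=O)CCCCCCc3ccccc3)o2)nc1` gives 2.1 nM, and compound 3 `COC(=O)CCCCc1cnc(C(=O)CCCCCCc2ccccc2)o1` gives 1.8 nM. Compound 3 sits within the usual scatter of both others, so the three numbers cannot be told apart.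

Compound 4 `CSCCCCCc1cnc(C(=O)CCCCCCc2ccccc2)o1` has not yet been measured. It differs from compound 3 in one place: (methylsulfanyl)methyl in place of methoxycarbonyl on a saturated chain carbon, four bonds along the chain from an aromatic carbon.

Two measured steps speak to this change. The step of a 1.2-fold lower number from compound 1 to compound 3 (0.09 log units; within the scatter) replaces the whole group on the aromatic carbon of the shared core, and the step of a 1.0-fold lower number from compound 1 to compound 2 (0.02 log units; within the scatter) alters the outer end of that group; neither moves the number beyond the scatter. Because a 1.2-fold lower number from compound 1 to compound 3 (0.09 log units; within the scatter) stayed flat even when the group on that carbon was exchanged entirely, a smaller exchange at the far end of the chain is expected to give no step beyond the scatter, so the expected step is a 1.1-fold higher number from compound 3 to compound 4 (0.05 log units; within the scatter).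

Compound 4 is therefore estimated at 2 nM, within a range from 0.7 nM to 6 nM.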

Compound 4, inhibition constant: 8.1 nM
Compound 4: the middle estimate sits 4.1-fold (0.61 log units) below what was measured; the whole stated range lies below it.
By their numbers in this assay, from the lowest: compounds 3, 2 and 1 (each within the scatter of the next); then compound 4.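

In this assay the far end of this chain turns out not to be free to change at will: replacing methoxycarbonyl with (methylsulfanyl)methyl gives a 4.5-fold higher number from compound 3 to compound 4 (0.65 log units; beyond the scatter) and shows that this position can move the number. Compound 4 also parts from the aldehyde-bearing compound, with a 3.7-fold higher number from compound 1 to compound 4 (0.57 log units; beyond the scatter) when the whole group on the aromatic carbon is compared, whereas the earlier exchange of that group stayed within the scatter. Nothing shown here says why the number rises.

The swap removes methoxycarbonyl and brings in sulfur in one step, and the compounds shown leave open which of the two matters. Also open, going by these compounds, is how a carboxylic acid or an amide at the end of the same chain would compare.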